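Swapping the thiophene for iodine on the shared core

The source may hold more compounds than are shown below. What is called first, only, known or untested is meant among the compounds shown, and "the series" means these compounds.

The compounds here share the core of compound 1, `COc1ncnc2c1c(-c1cccs1)cn2[C@@H]1O[C@H](CO)[C@@H](O)[C@H]1O`, a nucleoside bearing a methoxy group and a thiophen-2-yl group, and they were examined in an ADME assay on MRC5 cells (Homo sapiens), read by MTT assay, with a stated time of 72 h; on this read-out higher numbers stand for weaker inhibition and lower numbers for stronger inhibition. Among the measured compounds shown here, compound 1 gives 43200 nM, and it is the only compound of the three for which a number rather than a limit is reported. Compound 2, `Cc1ncnc2c1c(-c1cccs1)cn2[C@@H]1O[C@H](CO)[C@@H](O)[C@H]1O`, carries a methyl in place of the methoxy on an aromatic carbon and reaches only the limit of the assay, > 100000 nM. Compound 3, `CNc1ncnc2c1c(-c1cccs1)cn2[C@@H]1O[C@H](CO)[C@@H](O)[C@H]1O`, carries a methylamino in place of the methoxy and likewise sits at the limit, > 100000 nM. The recorded steps are an at least 2.3-fold higher number from compound 1 to compound 2 (0.36 log units; beyond the scatter) and an at least 2.3-fold higher number from compound 1 to compound 3 (0.36 log units; beyond the scatter), while the pair of limits leaves a step that the two limits leave unreadable from compound 2 to compound 3; these steps are shaped by the limit of > 100000 nM in this assay, at which 2 of the 3 values shown sit.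

Compound 4, `COc1ncnc2c1c(I)cn2[C@@H]1O[C@H](CO)[C@@H](O)[C@H]1O`, differs from compound 1 at a different place: iodo in place of thiophen-2-yl on an aromatic carbon. For the measured compounds named here, none of the measured steps touches this position, so none of them bears on the change, and the expectation can rest only on where compound 1 itself stands. Compound 4 is therefore expected to remain near compound 1, with an estimated 1.4-fold higher number from compound 1 to compound 4 (0.14 log units; within the scatter) toward weaker inhibition and a fair chance of reaching the limit. The estimate for compound 4 in this assay is 60000 nM, within the range 15000 nM to 150000 nM.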

Compound 4, half-maximal inhibitory concentration: 63000 nM
Beside the measured number, compound 4's estimate is 1.1-fold (0.02 log units) below it, and the stated range covers the measured number.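

Iodo in place of thiophen-2-yl gives a 1.5-fold higher number from compound 1 to compound 4 (0.16 log units; within the scatter) in this assay. Among the compounds shown here, this is the first view of this position, on an aromatic carbon of the five-membered aromatic ring, and it shows that the whole thiophen-2-yl group, with its 5 heavy atoms and its ring, can give way to a single iodine atom without a change beyond the scatter. The earlier steps shown here showed a read-out that responds beyond the scatter to changing the methoxy group, whereas this step shows no such response to this change at the second position, and compound 4 still gives a number rather than a limit.

The compounds shown leave open whether a different kind of group at this position, such as an amine, a carboxylic acid or a longer alkyl chain, would move the read-out beyond the scatter. They also leave open how iodo would read alongside methyl or methylamino in place of methoxy, and the readings for compound 2 and compound 3 are limits and not numbers: the limit of > 100000 nM in this assay, at which 2 of the 4 values shown sit.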